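The compounds below may be only part of what the source reports. "The series", "measured", "known", "first", "only" and "open" are said of these compounds alone.

Measured compounds:
compound 1 `COc1c(N2C[C@H]3CCCN(C(=O)Cn4cc(CN5C(=O)C(=O)c6cc(F)ccc65)nn4)[C@H]3C2)c(F)cc2c(=O)c(C(=O)O)cn(C3CC3)c12` — 16 ug/mL
compound 2 `COc1c(N2C[C@H]3CCCN(C(=O)Cn4cc(CN5C(=O)C(=O)c6cc(C)ccc65)nn4)[C@H]3C2)c(F)cc2c(=O)c(C(=O)O)cn(C3CC3)c12` — 64 ug/mL
compound 3 `CO/N=C1/C(=O)N(Cc2cn(CC(=O)N3CCC[C@@H]4CN(c5c(F)cc6c(=O)c(C(=O)O)cn(C7CC7)c6c5OC)C[C@@H]43)nn2)c2ccc(F)cc21` — 32 ug/mL

In an ADME assay on Vero cells (Chlorocebus sabaeus) for cytotoxicity, read by MTT assay, with a stated time of 72 h (on this read-out higher numbers stand for lower toxicity in this test and lower numbers for higher toxicity in this test), compound 1 gives 16 ug/mL, and compound 2 gives 64 ug/mL. The change between them is methyl in place of fluoro on an aromatic carbon, and it produced a 4.0-fold higher number from compound 1 to compound 2 (0.60 log units; beyond the scatter). Compound 3 gives 32 ug/mL in this assay; how its core differs from that of compound 1 is not broken down here. Compound 4 `CO/N=C1/C(=O)N(Cc2cn(CC(=O)N3CCC[C@@H]4CN(c5c(F)cc6c(=O)c(C(=O)O)cn(C7CC7)c6c5OC)C[C@@H]43)nn2)c2ccc(C)cc21` has not yet been measured in this assay. It differs from compound 3 by methyl in place of fluoro on an aromatic carbon, the same change as that from compound 1 to compound 2. Among the measured compounds shown here, the step for compound 4 is expected to be a 3.1-fold higher number from compound 3 to compound 4 (0.49 log units; beyond the scatter), resting on the single earlier step of a 4.0-fold higher number from compound 1 to compound 2 (0.60 log units; beyond the scatter) made by this same change. In this assay compound 4 is therefore estimated at 100 ug/mL, expected between 50 ug/mL and 250 ug/mL.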

Compound 4, half-maximal cytotoxic concentration: 64 ug/mL
Compound 4: the middle estimate sits 1.6-fold (0.19 log units) above what was measured; low and high end bracket the measured number.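

In this assay, methyl in place of fluoro gave a 2.0-fold higher number from compound 3 to compound 4 (0.30 log units; within the scatter), so on this core the step alone cannot be told apart from the scatter of repeated measurements. Set beside the earlier step, it does not differ from it: the same change on two cores in this assay, a 4.0-fold higher number (0.60 log units; beyond the scatter) from compound 1 to compound 2 and a 2.0-fold higher number (0.30 log units; within the scatter) from compound 3 to compound 4, 2.0-fold (0.30 log units) apart, within the scatter of two such steps. The two steps are therefore compatible with one effect of similar size on both cores, but this does not establish a real step on the core of compound 3, and two cores cannot show that the change would carry to others in this series.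

The compounds shown leave open how a chloro or methoxy group would behave on this aromatic carbon. They also leave open whether the step would persist if an amide replaced the carboxylic acid shared by all four compounds.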